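The compounds below may be only part of what the source reports. "The series", "measured", "known", "first", "only" and "open" are said of these compounds alone.

Compound 3 `Cc1ccccc1C#Cc1ccc2c(n1)CCN(C(C)C)C2=O` carries an isopropyl on the amide-type nitrogen of its ring. In an assay on HEK293 cells for displacement of a labelled ligand from metabotropic glutamate receptor 5 (Homo sapiens), with a stated time of 2 h (a higher number here means a weaker inhibitor, a lower number a stronger inhibitor), compound 3 gives only > 32000 nM, which is a limit of the assay rather than a number. Compound 1 `Cc1ccccc1C#Cc1ccc2c(n1)CCN(C)C2=O` has a methyl on that nitrogen instead. In this assay compound 1 gives > 32000 nM, again a limit. Because both sit at the limit of > 32000 nM in this assay, at which 2 of the 3 values shown sit, the step that the two limits leave unreadable from compound 1 to compound 3 cannot be read. Compound 2 `CN1CCc2nc(C#Cc3ccccn3)ccc2C1=O` gives 6240 nM in this assay, and the step of an at least 5.1-fold lower number from compound 1 to compound 2 (0.70 log units; beyond the scatter) concerns a different place. Compound 4 `CC(C)N1CCc2nc(C#Cc3ccccc3Cl)ccc2C1=O` carries chloro in place of methyl on an aromatic carbon. Within the data shown here, no measured step touches that change, so no step beyond the scatter is expected: an at least 1.0-fold lower number from compound 3 to compound 4 (0.02 log units; that floor lies within the scatter). Compound 4 is therefore expected to give roughly 30000 nM, within 8000 nM to 100000 nM.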

Compound 4, inhibition constant: 5680 nM
Estimate against measurement, compound 4: 5.3-fold (0.72 log units) above, and the stated range ends above it.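

In this assay, putting chloro in place of methyl on the aromatic carbon gives an at least 5.6-fold lower number from compound 3 to compound 4 (0.75 log units; beyond the scatter), so this single swap is enough to bring a compound off the limit. Among the earlier compounds, only replacing the whole 2-methylphenyl with pyridin-2-yl had done that. As far as these compounds go, the full size of the new step stays unknown because compound 3 has only a limit: the limit of > 32000 nM in this assay, at which 2 of the 4 values shown sit. From the compounds shown here alone, it remains open how bromo or methoxy would behave at this place. Going by these compounds, it is also open whether 2-chlorophenyl gives a similar number with methyl on the ring nitrogen.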